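The source may hold more compounds than are shown below. What is called first, only, known or untested is meant among the compounds shown, and "the series" means these compounds.

Compound 1 `O=c1[nH]nc(NCc2ccccc2)cc1-c1ccccc1`: in an assay for inhibition of casein kinase I isoform alpha (Sus scrofa), read by scintillation counting and 33P incorporation, with a stated time of 30 min, in the presence of a further agent that is not named here (a higher number here means a weaker inhibitor, a lower number a stronger inhibitor), compound 1 gives > 10000 nM, which is a limit of the assay rather than a number.
Compound 2 `CCCNc1cc(-c2ccccc2)c(=O)[nH]n1`: in this assay compound 2 gives > 10000 nM, again a limit and not a number.
Compound 3 `CC(=O)Nc1cc(-c2ccccc2)c(=O)[nH]n1`: in this assay compound 3 gives > 10000 nM, also a limit and not a number.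

The three compounds share one core and differ only in the group carried by the nitrogen on the aromatic ring: a benzyl, a propyl or an acetyl. Compound 3 stands where the other two stand, at the limit of > 10000 nM in this assay, at which 3 of the 3 values shown sit. The steps between them, a step that the two limits leave unreadable from compound 1 to compound 2, a step that the two limits leave unreadable from compound 1 to compound 3 and a step that the two limits leave unreadable from compound 2 to compound 3, have no readable size, since both ends of each step are limits; they show neither a direction nor a size beyond the scatter.

Compound 4 `O=C(Nc1cc(-c2ccccc2)c(=O)[nH]n1)c1ccccc1` differs from compound 3 by phenyl in place of methyl on a carbonyl carbon. Among the measured compounds shown here, none of the measured steps touches the carbonyl carbon, and none of them yields a number, so there is no measured guide to how large or in which direction the step from compound 3 to compound 4 will be. The expectation therefore stays with the three limits: the step is estimated as a step that the limit leaves unreadable from compound 3 to compound 4, that is, no change beyond the scatter. Compound 4 is expected to give 15000 nM in this assay, with a range from 3000 nM to 100000 nM, and most likely to be reported once more as a limit.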

Compound 4, half-maximal inhibitory concentration: > 10000 nM
Compound 4: a limit, no number; the forecaster's own chance of this, stated with the estimate: 80%; the middle value does not contradict the limit.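

Compound 3 and compound 4 both give a limit of the assay and not a number, so no size or direction can be read for the step between them, and compound 4 joins compound 1, compound 2 and compound 3: the limit of > 10000 nM in this assay, at which 4 of the 4 values shown sit.

The compounds shown leave open whether any group on this nitrogen of the shared core gives a measurable value in this assay.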